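Swapping the amine on the side chain of compound 3

A few compounds are considered here, and "the series" means these few. Any claim that something is new, unique, unknown or untested is made for them only; others in the source may bear on it.

Of the compounds shown here, three sharing one core have been measured in a functional assay on PC-3 cells (Homo sapiens) for cytotoxicity, read by MTT assay, with a stated time of 48 h; on this read-out higher numbers stand for weaker inhibition and lower numbers for stronger inhibition. Compound 1 `CC1=NN(C(=O)c2ccc(C)cc2)C(c2ccccc2O)C1` gives 40600 nM, and compound 2 `CC1=NN(C(=O)c2ccc(C)cc2)C(c2cc(Br)cc(Br)c2O)C1`, which carries two bromine atoms on its phenol ring, gives 41200 nM. Compound 3 `CCN(CC)CC(=O)N1N=C(C)CC1c1ccccc1O` gives 25900 nM in this assay, the lowest of the three numbers, yet its gaps to compound 1 and to compound 2 are both within the usual scatter, so no real ordering can be read from them.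

For the measured compounds named here, the one single-point step among the measured compounds, a 1.6-fold lower number from compound 1 to compound 3 (0.20 log units; within the scatter), swaps the group on the carbonyl carbon and leaves the number essentially unchanged.

Compound 4 `CC1=NN(C(=O)CN2CCC(Cl)CC2)C(c2ccccc2O)C1` differs from compound 3 in one place: 4-chloropiperidin-1-yl in place of diethylamino on a saturated chain carbon bound to a carbonyl carbon. Going by the values given here, no measured step touches this kind of exchange, a change of the amine itself rather than of the group on the carbonyl carbon, so there is nothing to lean on beyond the observation that the only change tried so far at this side chain, that from compound 1 to compound 3, stayed within the scatter. On that basis the expected step of a 1.0-fold lower number from compound 3 to compound 4 (0.02 log units; within the scatter) is none beyond the scatter. Compound 4 is therefore estimated at 25000 nM in this assay, within a range from 10000 nM to 65000 nM.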

Compound 4, half-maximal inhibitory concentration: 34800 nM
Compound 4: middle estimate off by 1.4-fold (0.14 log units), on the low side; low and high end bracket the measured number.
By their numbers in this assay, from the lowest: compounds 3, 4, 1 and 2 (each within the scatter of the next).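

In this assay, the exchange of diethylamino for 4-chloropiperidin-1-yl gives a 1.3-fold higher number from compound 3 to compound 4 (0.13 log units; within the scatter) and is the first step shown that alters the amine itself rather than the whole group on the carbonyl carbon. At this saturated chain carbon, an open-chain amine can therefore give way to one with a six-membered non-aromatic ring and a chlorine, going from 5 to 7 heavy atoms, with no change that can be told apart from the scatter of repeated measurements. No measurement at hand bears on the reason for this result.

These compounds leave open whether a morpholin-4-yl or piperazin-1-yl group on the same chain carbon, or a longer chain joining the amine to the carbonyl carbon, would shift the number beyond the scatter. They also cannot separate the contribution of the ring in compound 4 from that of its chlorine, a question that a plain piperidin-1-yl group on that carbon would help to answer.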